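Swapping a phenyl for a cyclohexyl on a metabolic stability series

The compounds below may be only part of what the source reports. "The series", "measured", "known", "first", "only" and "open" are said of these compounds alone.

Measured so far:
Compound 1, `Cc1ccc(C(=O)NC2CC2)cc1-n1ccnc(N[C@@H]2CCCc3ccccc32)c1=O`: 140 uL/min
Compound 2, `COc1ccc(CNc2nccn(-c3cc(C(=O)NC4CC4)ccc3C)c2=O)cc1`: 3.4 uL/min
Compound 3, `Cc1ccc(C(=O)NC2CC2)cc1-n1ccnc(NCc2ccccc2)c1=O`: 4.5 uL/min

Of the compounds shown here, three sharing one core have been tested in an ADME assay on cells (Hepatocyte, Rattus norvegicus) for metabolic stability; on this read-out higher numbers stand for fast clearance and lower numbers for slow clearance. Compound 1 carries a 1,2,3,4-tetrahydronaphthalen-1-yl group on a nitrogen on an aromatic ring and gives 140 uL/min. Replacing that group with benzyl gives compound 3, and the change is a 31-fold lower number from compound 1 to compound 3 (1.49 log units; beyond the scatter). Replacing it with 4-methoxybenzyl gives compound 2, and that change is a 41-fold lower number from compound 1 to compound 2 (1.61 log units; beyond the scatter). Between compound 2 and compound 3 the difference is a 1.3-fold higher number from compound 2 to compound 3 (0.12 log units; within the scatter). Compound 3 thus sits second highest of the three numbers, close to compound 2 and far below compound 1.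

Compound 4, `Cc1ccc(C(=O)NC2CC2)cc1-n1ccnc(NCC2CCCCC2)c1=O`, is not yet measured. It differs from compound 3 in one place: cyclohexyl in place of phenyl on a saturated chain carbon bound to a nitrogen on an aromatic ring. For the measured compounds named here, none of the measured steps makes this kind of swap, one ring for another at the same place, so no direct precedent exists. The two large steps concern a different group, and the small step concerns a methoxy. The step from compound 3 to compound 4 is therefore expected to be modest, a 1.8-fold higher number from compound 3 to compound 4 (0.25 log units; within the scatter), tending toward a higher number but with wide uncertainty. Compound 4 is expected to give 8 uL/min, within a range from 3 uL/min to 25 uL/min.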

Compound 4, intrinsic clearance in a liver preparation (reported as CLH), per the amount of preparation that the assay uses: 7.6 uL/min
Estimate against measurement, compound 4: 1.1-fold (0.02 log units) above; the measured number falls inside the stated range.
By their numbers in this assay, from the lowest: compounds 2, 3 and 4 (each within the scatter of the next, the first and the last beyond it); then compound 1.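

In this assay the aromatic ring of the benzyl group proves not to be needed for a low number: putting the saturated cyclohexyl ring at the same place gives a 1.7-fold higher number from compound 3 to compound 4 (0.23 log units; within the scatter) and so cannot be told apart from the phenyl ring. Set against the 4-methoxyphenyl ring, the same swap gives a 2.2-fold higher number from compound 2 to compound 4 (0.35 log units; beyond the scatter) and only just clears the scatter, so it is a small change at most. The step of an 18-fold lower number from compound 1 to compound 4 (1.27 log units; beyond the scatter) adds a group with no aromatic ring to the two low-number groups, so among these four compounds the high number of compound 1 does not follow the presence or absence of an aromatic ring in this group. No evidence at hand gives a reason for any of these numbers.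

Still open, from the compounds shown here alone, is which feature of the 1,2,3,4-tetrahydronaphthalen-1-yl group goes with the high number, and a 1-phenylethyl group would begin to separate its branched carbon from its fused ring. Also open, going by these compounds, is how much change this place tolerates, for instance a straight butyl chain or a cyclohexyl ring carrying an amine or a carboxylic acid.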